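The compounds below may be only part of what the source reports. "The series", "measured", "known", "first", "only" and "open" are said of these compounds alone.

Compound 1 `O=C(Nc1cccc(CNc2nccnc2Cl)c1)Nc1cccc2ccccc12`: > 40000 nM
Compound 2 `O=C(Nc1cccc(CNc2nccnc2Cl)c1)Nc1ccc(Cl)cc1Br`: 6650 nM

Of the compounds shown here, two have so far been tested in a functional assay on T-24 cells (Homo sapiens) for antiproliferative activity, read by MTT assay, with a stated time of 48 h; on this read-out higher numbers stand for weaker inhibition and lower numbers for stronger inhibition. For compound 1 the entry > 40000 nM is a limit of the assay rather than a number (the limit of > 40000 nM in this assay, at which 1 of the 2 values shown sits). Going by the values given here, compound 2, which gives 6650 nM in this assay, therefore stands as the only real number in the set, and nothing else can be ranked against it.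

Compound 3 `COc1ccccc1NC(=O)Nc1cccc(CNc2nccnc2Cl)c1` has not yet been measured. It differs from compound 2 in one place: 2-methoxyphenyl in place of 2-bromo-4-chlorophenyl on an amide-type nitrogen. Among the compounds with values here, no measured pair shows what such a swap does here, so the expectation rests on the change alone. A step toward weaker inhibition, larger than the usual scatter, is expected in this assay, with a real chance that only a limit is returned. For compound 3 the estimated value is 15000 nM, between 4000 nM and 40000 nM, which corresponds to an expected step of a 2.3-fold higher number from compound 2 to compound 3 (0.35 log units; beyond the scatter).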

Compound 3, half-maximal inhibitory concentration: 10400 nM
Compound 3: the middle estimate sits 1.4-fold (0.16 log units) above what was measured; measured number inside the range.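

On this amide-type nitrogen, 2-methoxyphenyl and 2-bromo-4-chlorophenyl cannot be told apart in this assay: the swap gives a 1.6-fold higher number from compound 2 to compound 3 (0.19 log units; within the scatter). In this one pair, the bromine and chlorine can both leave and an oxygen-bearing group can enter with no difference that stands clear of the scatter. Compound 1 remains a limit of the assay rather than a number, so steps involving it cannot be read: the limit of > 40000 nM in this assay, at which 1 of the 3 values shown sits.

From the compounds shown here alone, compound 3 differs from compound 2 in its bromine, chlorine and methoxy group all at once, so what each contributes alone stays open. Going by these compounds, it also stays open whether a phenyl ring carrying an amine or a carboxylic acid at this place would give a clearly different number.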